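Swapping a pyridine for a phenyl on an indole core

This account rests on a few compounds, and the source may have more. Where it says the series, first, only, none or still open, it means among the compounds named here.

Measured compounds and their inhibition values:
- compound 1, `O=[N+]([O-])c1ccc2[nH]c(-c3cccnc3)cc2c1`: 27.9%
- compound 2, `Nc1ccc2[nH]c(-c3ccc(Cl)c(Cl)c3)cc2c1`: 21.4%
- compound 3, `Nc1ccccc1C#Cc1cc(F)cc(F)c1`: 9.27%

All three were tested in an assay on isolated protein for inhibition of Aromatase (Homo sapiens), read by fluorescence, using NADPH, with a stated time of 30 min, tested at 50 uM; on this read-out higher numbers stand for more inhibition at the one concentration tested (going by the name of the read-out) and lower numbers for less inhibition. Compound 1 gives the highest of the three numbers, yet compound 2 lies within the usual scatter of it, so no order between those two can be claimed. Among the compounds with values here, compound 3, the only one without the fused core of compound 1, lies clearly lower, beyond the scatter.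

Compound 4, `O=[N+]([O-])c1ccc2[nH]c(-c3ccccc3)cc2c1`, has not yet been measured. It differs from compound 1 in one place: phenyl in place of pyridin-3-yl on an aromatic carbon. Within the data shown here, nothing in the measured set shows a pair differing in just this way, so no measured step can be quoted. With the ring nitrogen of the pyridin-3-yl removed and nothing else changed, a moderate fall is the expectation here rather than a rise. The expected step of a number 12.9 percentage points lower from compound 1 to compound 4 (beyond the scatter) would leave compound 4 in this assay somewhat below compound 1. Compound 4 is therefore estimated at 15%, with a likely range from 3% to 30%.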

Compound 4, a percentage reported as inhibition, at one concentration (the size of the read-out at that concentration, not a potency): 77.7%
Compound 4: the middle estimate sits 62.7 percentage points below what was measured, outside the stated range (above it).
By their numbers in this assay, from the lowest: compound 3; then compounds 2 and 1 (each within the scatter of the next); then compound 4.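

Phenyl in place of pyridin-3-yl on an aromatic carbon next to the ring nitrogen gives a number 49.8 percentage points higher from compound 1 to compound 4 (beyond the scatter) in this assay. Within the data shown here, this is the first reading of a single change in this set, and it shows that this place on the core is far from indifferent: with the rest of the molecule unchanged, exchanging the ring nitrogen of the pyridin-3-yl for carbon is enough to produce a large step. Nothing available explains why the number rises so far.

From the compounds shown here alone, whether other groups at this place, such as cyclohexyl or thienyl, would match phenyl remains open. Also open, going by these compounds, is whether the step would hold with a nitrile or a carboxylic acid in place of the nitro group, since it has been read only with the nitro group present.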